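The source may report more compounds than this note shows. Statements on the series, on what has been measured and on what is new or still open speak of the compounds shown alone.

Measured so far in a functional assay, read by spectrophotometry, with a stated time of 1 h; on this read-out higher numbers stand for weaker inhibition and lower numbers for stronger inhibition:
- Compound 1 `Nc1ccccc1/N=C\c1cc(=O)oc2cc(OCc3ccccc3)ccc12`: 34600 nM.
- Compound 2 `O=c1cc(/C=N\Nc2ccc([N+](=O)[O-])cc2)c2ccc(OCc3ccccc3)cc2o1`: > 2000000 nM, which is a limit of the assay and not a number.

Compound 2 stands at the weak end of these two results, and all that can be said of it is the limit of > 2000000 nM in this assay, at which 1 of the 2 values shown sits. Compound 3 `O=c1cc(/C=N\Nc2ccccc2)c2ccc(OCc3ccccc3)cc2o1` has not yet been measured. It differs from compound 2 in one place, hydrogen in place of nitro on an aromatic carbon, para to a large group. The same difference can be read as 4-nitrophenyl to phenyl.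

Among the compounds with values here, only one measured step bears on this part of the molecule: an at least 57-fold higher number from compound 1 to compound 2 (1.76 log units; beyond the scatter). That step is large, but it swaps a whole group, (4-nitrophenyl)amino in place of 2-aminophenyl, so it cannot show how much of the loss belongs to the nitro alone. Compound 3 keeps the anilino part and drops the nitro, so it is expected to recover some of that loss, giving a lower number and stronger inhibition. The expected change is an at least 13-fold lower number from compound 2 to compound 3 (1.12 log units; beyond the scatter). The estimate for compound 3 is 150000 nM, with an expected range from 30000 nM to 1000000 nM.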

Compound 3, half-maximal inhibitory concentration: 455000 nM
Compound 3: middle estimate off by 3.0-fold (0.48 log units), on the low side; the measured number falls inside the stated range.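

In this assay, within the data shown here, taking away the nitro group and changing nothing else gives an at least 4.3-fold lower number from compound 2 to compound 3 (0.64 log units; beyond the scatter), which is the first view of the nitro group on its own, since the earlier step swapped a whole group. Compound 2 is held at a limit of the assay and not at a number, so this step gives only a smallest possible size for what the nitro group costs, and the true size could be larger: the limit of > 2000000 nM in this assay, at which 1 of the 3 values shown sits. Even with the nitro group gone, a 13-fold higher number from compound 1 to compound 3 (1.12 log units; beyond the scatter) remains, so the nitro group does not account for the whole loss seen earlier, and the swap of 2-aminophenyl for anilino carries a large loss of its own.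

The compounds shown hold only nitro and hydrogen at this place on the ring, so they leave open how an amine or a methoxy group there would read. They also leave open which part of the swap from 2-aminophenyl to anilino carries that large step, the amine on the ring or the extra nitrogen in the link.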